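Methyl removal next to ring nitrogen across two cores

The compounds below may be only part of what the source reports. "The series", "measured", "known", "first", "only" and "open" are said of these compounds alone.

Compound 1, `N/C(=N\NC(=S)N1CCCCCC1)c1ccccn1`, gives 86.5% in a functional assay on A-375 cells (Homo sapiens) for cytotoxicity, read by MTT assay, with a stated time of 72 h, tested at 10 uM; on this read-out lower numbers stand for less inhibition of growth and higher numbers for more inhibition of growth at the one concentration tested.
Compound 2, `Cc1cccc(/C(N)=N/NC(=S)N2CCCCCC2)n1`, gives 79.9% in this assay.
Compound 3, `Cc1cccc(/C(N)=N/NC(=S)N2CCCC2)n1`, gives 55.9% in this assay.

Compound 3 is lowest of the three; its values to compound 2 and compound 1 both lie beyond the scatter. Compound 4, `N/C(=N\NC(=S)N1CCCC1)c1ccccn1`, is not yet measured in this assay. It differs from compound 3 by hydrogen in place of methyl on an aromatic carbon. The same change has been made once, from compound 2 to compound 1: hydrogen in place of methyl on an aromatic carbon, with a number 6.6 percentage points higher from compound 2 to compound 1 (within the scatter). The difference between the two cores is not broken down here. Because the earlier step of a number 6.6 percentage points higher from compound 2 to compound 1 (within the scatter) lay within the scatter, a step of similar size is expected for compound 4, a number 7.1 percentage points higher from compound 3 to compound 4 (within the scatter). Compound 4 is therefore estimated at 63%, with a range from 46% to 80%.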

Compound 4, percent growth inhibition at one concentration: 83.9%
Estimate against measurement, compound 4: 20.9 percentage points below; measured number outside the range, above it.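

Exchanging methyl for hydrogen on an aromatic carbon next to the ring nitrogen does not carry over at one size between the two cores in this assay: the same change on two cores in this assay, a number 6.6 percentage points higher (within the scatter) from compound 2 to compound 1 and a number 28 percentage points higher (beyond the scatter) from compound 3 to compound 4, 21.4 percentage points apart, beyond the scatter of two such steps

The new pair gives a number 28 percentage points higher from compound 3 to compound 4 (beyond the scatter), so a step read on one core did not predict the step on the other. Two pairs show that the size of this step can depend on the core, but they give no rule for other cores and do not explain the gap.

At this position the compounds shown carry only methyl or hydrogen, which leaves open how a chlorine atom, a methoxy group or an amine would read. Also open, as far as these compounds go, is whether an open-chain dimethylamino group in place of the saturated ring would follow either step.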